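The compounds below may be only part of what the source reports. "The series", "measured", "known", "first", "only" and "open" are said of these compounds alone.

Measured compounds in an ADME assay on SW480 cells (Homo sapiens) for cytotoxicity, read by MTT assay, with a stated time of 72 h; on this read-out lower numbers stand for stronger inhibition and higher numbers for weaker inhibition:

- compound 1 `O=C(NCC1CCCCC1)c1cccc(/C=C2\CC(=O)N(c3ccccc3)C2=O)c1` gives > 100000 nM, a limit of the assay and not a number
- compound 2 `CCc1cccc(NC(=O)c2cccc(/C=C3\CC(=O)N(c4ccccc4)C3=O)c2)c1` gives 88600 nM
- compound 3 `Cc1ccc(NC(=O)c2cccc(/C=C3\CC(=O)N(c4ccccc4)C3=O)c2)cc1` gives > 100000 nM, again a limit of the assay and not a number

Compound 3 therefore stands at the edge of what this assay can report: its value is only a limit. Within the data shown here, the same holds for compound 1, and the one number that was read, for compound 2, lies close to that edge; this is what the limit of > 100000 nM in this assay, at which 2 of the 3 values shown sit, says about the three values shown. The step of an at least 1.1-fold higher number from compound 2 to compound 3 (0.05 log units; that floor lies within the scatter) and the step of an at least 1.1-fold lower number from compound 1 to compound 2 (0.05 log units; that floor lies within the scatter) are both tiny floors that stay within the usual scatter, and the step that the two limits leave unreadable from compound 1 to compound 3 cannot be read at all.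

Compound 4 `Cc1cccc(NC(=O)c2cccc(/C=C3\CC(=O)N(c4ccccc4)C3=O)c2)c1` differs from compound 3 in one place: 3-methylphenyl in place of 4-methylphenyl on an amide-type nitrogen. All measured steps here swap one group on that same amide-type nitrogen, and none of them moved the read-out beyond the scatter, so the step of a number no higher from compound 3 to compound 4 (the limit leaves the size open) is expected to be no larger than the scatter. For compound 4 the estimate is 100000 nM, with a range from 50000 nM to 200000 nM, and it is expected that this assay may again report only a limit.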

Compound 4, half-maximal inhibitory concentration: > 100000 nM
Compound 4 gave a limit, no number (the forecaster's own chance of this, stated with the estimate: 60%); the middle value sits exactly at the limit.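

Moving from 4-methylphenyl to 3-methylphenyl on the amide-type nitrogen leaves compound 4, like compound 3, at a limit and not a number in this assay, so the steps linking compound 4 to compound 1 and to compound 3 cannot be read, and this change of methyl placement shows no difference that can be sized. Among these compounds, the one step that can be read, hydrogen in place of methyl on a saturated chain carbon bound to an aromatic carbon, is an at least 1.1-fold higher number from compound 2 to compound 4 (0.05 log units; that floor lies within the scatter), so the 3-ethylphenyl of compound 2 and the 3-methylphenyl of compound 4 cannot be told apart here. With compound 4 added, this group on the amide-type nitrogen has been varied further without any value clearly moving away from the edge of the read-out: the limit of > 100000 nM in this assay, at which 3 of the 4 values shown sit.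

The compounds shown leave open whether any group on that nitrogen can bring a value well clear of the limit, for instance a phenyl carrying an amine or a carboxylic acid, or a longer chain. They also leave open whether compound 3 and compound 4 differ at all, since a limit hides any gap between them.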